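Changing the benzyl group on a shared core: compound 4

A few compounds are considered here, and "the series" means these few. Any claim that something is new, unique, unknown or untested is made for them only; others in the source may bear on it.

Three compounds that share one core differ only in the aromatic ring carried on a saturated chain carbon bound to an amine nitrogen in a ring. Compound 1 `O=C(N[C@H]1CCN(Cc2ccc(C(F)(F)F)cc2)C1)c1ccc(-c2cccs2)cc1` gives 14 nM in an assay on HEK298 cells for displacement of a labelled ligand from D(4) dopamine receptor (Homo sapiens); a higher number here means a weaker inhibitor, a lower number a stronger inhibitor. Compound 2 `O=C(N[C@H]1CCN(Cc2cccc(C(F)(F)F)c2)C1)c1ccc(-c2cccs2)cc1` gives 22 nM in this assay, and compound 3 `O=C(N[C@H]1CCN(Cc2ccc(Cl)c(Cl)c2)C1)c1ccc(-c2cccs2)cc1` gives 15 nM. The three steps between them, a 1.6-fold higher number from compound 1 to compound 2 (0.20 log units; within the scatter), a 1.1-fold higher number from compound 1 to compound 3 (0.03 log units; within the scatter) and a 1.5-fold lower number from compound 2 to compound 3 (0.17 log units; within the scatter), all stay within the scatter, so none of the three can be set apart from the others. Compound 3 stands second highest of the three numbers, nearest to compound 1 and furthest from compound 2, with both gaps within the scatter.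

Compound 4 `O=C(N[C@H]1CCN(Cc2ccccc2F)C1)c1ccc(-c2cccs2)cc1` is not yet measured. The change from compound 3 is 2-fluorophenyl in place of 3,4-dichlorophenyl on a saturated chain carbon bound to an amine nitrogen in a ring. All three measured steps touch the same place and swap one substituted phenyl for another, and each of them stayed within the scatter. On that basis a step of about a 1.7-fold higher number from compound 3 to compound 4 (0.22 log units; within the scatter) is expected, with no clear direction beyond the scatter. Compound 4 is therefore estimated at 25 nM in this assay, within a range of 8 nM to 80 nM.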

Compound 4, inhibition constant: 33 nM
The estimate for compound 4 lay 1.3-fold (0.12 log units) below the measured number; the range from low to high includes it.
By their numbers in this assay, from the lowest: compounds 1, 3, 2 and 4 (each within the scatter of the next, the first and the last beyond it).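

For the compounds shown here, until now every swap of one substituted phenyl for another on a saturated chain carbon bound to an amine nitrogen in a ring stayed within the scatter in this assay, but 2-fluorophenyl gives the first steps beyond it, with a 2.2-fold higher number from compound 3 to compound 4 (0.34 log units; beyond the scatter) and a 2.4-fold higher number from compound 1 to compound 4 (0.37 log units; beyond the scatter) both counting as modest. This position is thus not wholly indifferent to the ring it carries, yet the split is not clean: with a 1.5-fold higher number from compound 2 to compound 4 (0.18 log units; within the scatter) still within the scatter, 2-fluorophenyl cannot be set apart from 3-(trifluoromethyl)phenyl. Nothing shown here gives a reason for these steps.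

Going from 3,4-dichlorophenyl to 2-fluorophenyl changes both the halogen and its place on the ring, and these compounds cannot separate the two. A plain phenyl with no substituent would give a baseline for all four rings, while a methoxy group or an amine on the ring, or a longer chain between the ring and the amine nitrogen, would test how far this position tolerates larger changes.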